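A few compounds are considered here, and "the series" means these few. Any claim that something is new, unique, unknown or untested is made for them only; others in the source may bear on it.

Measured compounds:
Compound 1, `Cc1cccn2cc(-c3nnc(-c4ccc(Br)cc4)o3)nc12`, in a functional assay on DU-145 cells (Homo sapiens) for antiproliferative activity, read by MTT assay, with a stated time of 48 h (on this read-out lower numbers stand for stronger inhibition and higher numbers for weaker inhibition), compound 1 gives 38900 nM.
Compound 2, `Cc1cccn2cc(-c3nnc(-c4ccc(N(C)C)cc4)o3)nc12`, compound 2 gives 10800 nM.
Compound 3, `Cc1cc(Br)c2nc(-c3nnc(-c4ccc(Br)cc4)o3)cn2c1`, compound 3 gives 22300 nM.

Compound 1 and compound 2 share a core and differ in one place: dimethylamino in place of bromo on an aromatic carbon. That change made a step of a 3.6-fold lower number from compound 1 to compound 2 (0.56 log units; beyond the scatter), a modest gain that lies beyond the scatter. Compound 3 carries a different core; the difference between the two cores is not broken down here. Its value sits within the scatter of compound 1 and beyond the scatter of compound 2.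

Compound 4, `Cc1cc(Br)c2nc(-c3nnc(-c4ccc(N(C)C)cc4)o3)cn2c1`, has not yet been measured. It stands to compound 3 as compound 2 stands to compound 1: dimethylamino in place of bromo on an aromatic carbon. The place of the change is described in the same words in both pairs, so this is the same change made on the second core. Because the earlier step was a 3.6-fold lower number from compound 1 to compound 2 (0.56 log units; beyond the scatter), a step of similar size is expected here, so compound 4 is expected to show a 3.4-fold lower number from compound 3 to compound 4 (0.54 log units; beyond the scatter). The estimate rests on one prior instance only, which leaves the margin wide. For compound 4 the expected value is 6500 nM, with a likely range from 2500 nM to 16000 nM.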

Compound 4, half-maximal inhibitory concentration: 12800 nM
Estimate against measurement, compound 4: 2.0-fold (0.29 log units) below; the measured number falls inside the stated range.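

On the second core, in this assay, putting dimethylamino in place of bromo gives a 1.7-fold lower number from compound 3 to compound 4 (0.24 log units; within the scatter), a step that on its own cannot be told apart from no change. Set beside the step on the first core, it does not differ from that step by more than two such measurements allow: the same change on two cores in this assay, a 3.6-fold lower number (0.56 log units; beyond the scatter) from compound 1 to compound 2 and a 1.7-fold lower number (0.24 log units; within the scatter) from compound 3 to compound 4, 2.1-fold (0.32 log units) apart, within the scatter of two such steps This shows that the two results are compatible with one shared effect of the change, but it does not show that the gain seen on the first core carries over, nor that it is lost on the second, as the series offers only two pairs in one cell line.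

The compounds shown leave open how a morpholine ring, a primary amine or a carboxylic acid would behave in the same place on either core. Among the compounds shown here, they also leave open which part of the difference between the two cores matters, as no single pair here isolates it.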